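The source may hold more compounds than are shown below. What is called first, only, known or untested is meant among the compounds shown, and "the series" means these compounds.

Measured so far:
compound 1 `O=S(=O)(CC1=NCCS1)c1c(-c2ccccc2)nn(-c2ccccc2)c1-c1ccccc1` — "not active" (no number reported)
compound 2 `O=S(=O)(CC1=NCCS1)c1c(-c2ccc(Cl)cc2)nn(-c2ccccc2)c1-c1ccc(Cl)cc1` — "not active" (no number reported)
compound 3 `COc1ccc(-c2nn(-c3ccccc3)c(-c3ccc(C)cc3)c2S(=O)(=O)CC2=NCCO2)cc1` — 72.5%

In a functional assay, tested at 100 ug/mL (on this read-out lower numbers stand for a weaker effect and higher numbers for a stronger effect at the one concentration tested), compound 1 gives "not active" (no number reported) and no number stands behind it. Compound 2 in this assay likewise gives "not active" (no number reported) without a number, while compound 3 gives 72.5%. Compound 1 therefore stands among the entries without a figure; only compound 3 shows a measured effect.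

Compound 4 `O=S(=O)(CC1=NCCO1)c1c(-c2ccccc2)nn(-c2ccccc2)c1-c1ccccc1` is compound 1 with one change: a group of 5 heavy atoms (3 carbon, 1 nitrogen, 1 oxygen; one five-membered non-aromatic ring with 2 hetero atoms) in place of a group of 5 heavy atoms (3 carbon, 1 nitrogen, 1 sulfur; one five-membered non-aromatic ring with 2 hetero atoms), on a saturated chain carbon bound to a sulfonyl sulfur. Going by the values given here, compound 3 carries the same entering group on its chain carbon bound to the sulfonyl sulfur, but also differs on its aromatic rings, so the pair compound 1 and compound 3 does not isolate this change, and no step between measured compounds bears on it. Since compound 1 shows no reported effect and compound 3, which carries the entering group, gives 72.5%, a rise in this assay is expected for compound 4, of uncertain size, possibly beyond the scatter. Compound 4 is expected to give about 35% in this assay, within 0% to 75%.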

Compound 4, a percentage reported as activity, at one concentration (the size of the read-out at that concentration, not a potency): 59.1%
Estimate against measurement, compound 4: 24.1 percentage points below; low and high end bracket the measured number.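

No step can be read from compound 1 to compound 4: in this assay compound 1 gives "not active" (no number reported), which carries no number, while compound 4 gives 59.1%. The compounds shown leave open how large the effect of this ring exchange is. Nothing at hand bears on the result.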